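Amide nitrogen substituents: from compound 3 to compound 4

A few compounds are considered here, and "the series" means these few. Any claim that something is new, unique, unknown or untested is made for them only; others in the source may bear on it.

Measured in a functional assay (QGY7701 cells, Homo sapiens) for inhibition, read by MTT assay, with a stated time of 48 h; on this read-out lower numbers stand for stronger inhibition and higher numbers for weaker inhibition:
- compound 1 `COc1ccc(CNC(=O)/C=C/c2coc3cc(O)ccc3c2=O)cc1`: 10000 nM
- compound 2 `COc1ccc(NC(=O)/C=C/c2coc3cc(O)ccc3c2=O)cc1`: > 100000 nM (a limit of the assay)
- compound 3 `Cc1ccccc1NC(=O)/C=C/c1coc2cc(O)ccc2c1=O`: 9320 nM

Compound 3 at 9320 nM and compound 1 at 10000 nM lie within the scatter of each other. Compound 2 gives only a limit, not a number.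

Compound 4 `Cc1ccc(CNC(=O)/C=C/c2coc3cc(O)ccc3c2=O)cc1` carries 4-methylbenzyl in place of 2-methylphenyl on an amide-type nitrogen.

One measured step changes a group at this place: an at least 10-fold lower number from compound 2 to compound 3 (1.03 log units; beyond the scatter). It starts from the limit of > 100000 nM in this assay, at which 1 of the 3 values shown sits, so its true size is open, but it shows that a change here can be large. It offers no direction for the new group. With compound 1 at 10000 nM, the numbers available sit close together, so no shift beyond the scatter is expected in this assay, although a wide range is warranted. The expected step is a 1.1-fold higher number from compound 3 to compound 4 (0.03 log units; within the scatter). For compound 4 the estimated value is 10000 nM, with an expected range of 3500 nM to 35000 nM.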

Compound 4, half-maximal inhibitory concentration: 24900 nM
Beside the measured number, compound 4's estimate is 2.5-fold (0.40 log units) below it, within the range that was stated.
By their numbers in this assay, from the lowest: compounds 3 and 1 (each within the scatter of the next); then compound 4. At a limit, above all of these: compound 2.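

In this assay, the change from 2-methylphenyl to 4-methylbenzyl gives a 2.7-fold higher number from compound 3 to compound 4 (0.43 log units; beyond the scatter), so a measured step at this nitrogen now runs upward and not only downward. Among the compounds shown here, the benzyl group is also sensitive to its own ring substituent: methoxy and methyl give a 2.5-fold higher number from compound 1 to compound 4 (0.40 log units; beyond the scatter), a difference that the earlier compounds could not show. Only a bound can be given for an at least 4.0-fold lower number from compound 2 to compound 4 (0.60 log units; beyond the scatter), which starts from a limit: the limit of > 100000 nM in this assay, at which 1 of the 4 values shown sits.

The compounds shown do not separate the effect of the benzyl link from that of the methyl group's location, since 2-methylbenzyl and 4-methylphenyl are absent from them. On these data alone, how an unsubstituted benzyl, a chlorine on the benzyl ring or a longer chain such as 2-phenylethyl would read at this nitrogen remains open.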